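A few compounds are considered here, and "the series" means these few. Any claim that something is new, unique, unknown or untested is made for them only; others in the source may bear on it.

Compound 1 `CN(CCC#N)C[C@H]1CN(c2ccc(-n3cc(-c4ccccn4)cn3)c(F)c2)C(=O)O1` is the starting point. In an ADME assay on L02 cells (Homo sapiens) for cytotoxicity, read by MTT assay, with a stated time of 48 h (a lower number here means a stronger inhibitor, a higher number a weaker inhibitor), compound 1 gives > 400 ug/mL, which is a limit of the assay rather than a number. Going by the values given here, its single neighbour, compound 2 `O=C1O[C@@H](CSc2cccs2)CN1c1ccc(-n2cc(-c3ccccn3)cn2)c(F)c1`, differs from it in one place. In this assay compound 2 gives > 400 ug/mL, again a limit of the assay. Among the compounds with values here, the only measured step, a step that the two limits leave unreadable from compound 1 to compound 2, therefore cannot be sized, and what the data say of compound 1 is simply (the limit of > 400 ug/mL in this assay, at which 2 of the 2 values shown sit).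

Compound 3 `NC(=O)[C@H]1CN(c2ccc(-n3cc(-c4ccccn4)cn3)c(F)c2)C(=O)O1` carries carbamoyl in place of ((2-cyanoethyl)(methyl)amino)methyl on a saturated ring carbon. No readable step bears on this change, so no direction can be drawn from the measured pairs. The expected step of a number no higher from compound 1 to compound 3 (the limit leaves the size open) is accordingly none beyond the scatter. Compound 3 is expected to give 400 ug/mL in this assay, within 150 ug/mL to 800 ug/mL, most probably reported once more only as a limit.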

Compound 3, half-maximal inhibitory concentration: 119 ug/mL
Compound 3: middle estimate off by 3.4-fold (0.53 log units), on the high side; measured number below the stated range.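

Compound 3 alone gives a measured number rather than a limit, which shows that the group on this saturated ring carbon, next to the ring oxygen, can bear on the read-out in this assay. Carbamoyl in place of ((2-cyanoethyl)(methyl)amino)methyl gives an at least 3.3-fold lower number from compound 1 to compound 3 (0.52 log units; beyond the scatter), and carbamoyl in place of ((thiophen-2-yl)sulfanyl)methyl gives an at least 3.3-fold lower number from compound 2 to compound 3 (0.52 log units; beyond the scatter). The values of the two earlier compounds are limits of the assay and not numbers, so the full size of each step stays unknown: the limit of > 400 ug/mL in this assay, at which 2 of the 3 values shown sit.

The compounds shown leave open whether the lower number follows from the carbamoyl group itself or from the loss of either longer chain. A hydroxymethyl group, a carboxylic acid or a methyl ester on the same ring carbon would bear on that question.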